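This account rests on a few compounds, and the source may have more. Where it says the series, first, only, none or still open, it means among the compounds named here.

Measured in an ADME assay on L02 cells (Homo sapiens) for cytotoxicity, read by MTT assay; a lower number here means a stronger inhibitor, a higher number a weaker inhibitor:
- Compound 1 `C#CCOc1cc(/C=C/C(=O)c2ccc(OC)c3c2OC(C)(C)C=C3)ccc1OC`: > 10000 nM (a limit)
- Compound 2 `COc1ccc(/C=C/C(=O)c2ccc(OC)c3c2OC(C)(C)C=C3)cc1OCCO`: > 10000 nM (a limit)

Compound 1 stands at a limit and has no numerical value, so its position in this assay is only bounded. Compound 3 `CCCCC(=O)Oc1cc(/C=C/C(=O)c2ccc(OC)c3c2OC(C)(C)C=C3)ccc1OC` carries the change butylcarbonyl in place of propargyl on an oxygen on an aromatic ring.

Within the data shown here, the only measured step is a step that the two limits leave unreadable from compound 1 to compound 2. It gives no size to carry over, and the whole evidence is the limit of > 10000 nM in this assay, at which 2 of the 2 values shown sit. No direction can be read from it either. A change beyond the scatter is therefore not expected, and the estimated step is a step that the limit leaves unreadable from compound 1 to compound 3. A result reported only as a limit is the likeliest outcome.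

For compound 3 the estimate is 15000 nM, with an expected range of 6000 nM to 40000 nM.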

Compound 3, half-maximal inhibitory concentration: > 10000 nM
Compound 3: no number, only a limit (the forecaster's own chance of this, stated with the estimate: 75%); the middle value does not contradict the limit.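

No new step can be read among compound 1, compound 2 and compound 3, each of which is reported only as a limit: the limit of > 10000 nM in this assay, at which 3 of the 3 values shown sit. Still open, as far as these compounds go, is how far these compounds lie apart in this assay, and whether any group on this oxygen on an aromatic ring would give a numerical value.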